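A few compounds are considered here, and "the series" means these few. Any claim that something is new, unique, unknown or untested is made for them only; others in the source may bear on it.

Three analogues built on the same dihydropyrimidinone-type core were examined in an assay on membranes from CHO cells for displacement of a labelled ligand from adenosine receptor A1 (Homo sapiens), read by scintillation counting, with a stated time of 60 min, tested at 1 uM; a higher number here means more inhibition at the concentration tested (going by the name of the read-out), a lower number less inhibition. Compound 1 `CCCOC(=O)C1=C(C)N(C)C(=O)NC1c1cccs1` gives 9%, and compound 2 `CC1=C(C(=O)OCC(C)C)C(c2cccs2)NC(=O)N1C` gives 9%. Compound 3 `CCNC(=O)C1=C(C)NC(=O)NC1c1ccoc1` gives 1%; its value and those of compound 1 and compound 2 all lie within the scatter of one another, so no order among the three can be read from these numbers.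

The step of no change at the digits printed from compound 1 to compound 2 (within the scatter) corresponds to the change (methyl in place of hydrogen on a saturated chain carbon bound to two saturated chain carbons). The difference between the core of compound 3 and that of compound 1 is not broken down here.

Compound 4 `CC1=C(C(=O)NC(C)C)C(c2ccoc2)NC(=O)N1` has not yet been measured. It differs from compound 3 by methyl in place of hydrogen on a saturated chain carbon bound to an amide-type nitrogen and a saturated chain carbon. This is the same kind of change as from compound 1 to compound 2, though the surroundings differ: there the carbon was bound to two saturated chain carbons, here to an amide-type nitrogen and a saturated chain carbon. Because the earlier step of no change at the digits printed from compound 1 to compound 2 (within the scatter) was flat, the step of a number 2 percentage points higher from compound 3 to compound 4 (within the scatter) is expected to be small as well. Compound 4 is therefore estimated at 3%, with a likely range of -7% to 13%.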

Compound 4, a percentage reported as inhibition, at one concentration (the size of the read-out at that concentration, not a potency): 1%
Beside the measured number, compound 4's estimate is 2 percentage points above it; measured number inside the range.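

In this assay, the move from ethylcarbamoyl to isopropylcarbamoyl brought no change at the digits printed from compound 3 to compound 4 (within the scatter) and left compound 4 at 1%, so this methyl in place of hydrogen added nothing that can be read on this core. Set beside the earlier step, the same kind of change reads alike on the two cores: the same change on two cores in this assay, no change at the digits printed (within the scatter) from compound 1 to compound 2 and no change at the digits printed (within the scatter) from compound 3 to compound 4, 0 percentage points apart, within the scatter of two such steps. This shows agreement only between two flat steps at small readings taken at one concentration, in two different surroundings, a carbon bound to two saturated chain carbons and a carbon bound to an amide-type nitrogen and a saturated chain carbon, and it does not show that the change would stay flat on a core with clearly larger inhibition.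

The compounds shown leave open what a longer chain, such as hexyl, or a chain ending in an amine or a carboxylic acid would do in the same place. They also leave open how the cores themselves compare, as compound 1 and compound 3 differ in more than one place.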